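The compounds below may be only part of what the source reports. "The series", "measured", "known", "first", "only" and "open" are said of these compounds alone.

Of the compounds shown here, three built on one shared core have been tested in a functional assay on CHO cells for antagonist activity at prostaglandin E2 receptor EP3 subtype (Homo sapiens), read by cAMP accumulation; on this read-out higher numbers stand for weaker inhibition and lower numbers for stronger inhibition. Compound 1 `CC(C)C(c1ccc(-c2ccc3cccc(F)c3c2)[nH]c1=O)N1CCCCS1(=O)=O` gives 122 nM, the highest of the three numbers. Compound 2 `CC(C)C(Cc1ncc[nH]1)c1ccc(-c2ccc3cccc(F)c3c2)[nH]c1=O` gives 76 nM, and compound 3 `CC(C)C(c1nnc[nH]1)c1ccc(-c2ccc3cccc(F)c3c2)[nH]c1=O` gives 21 nM. The move to compound 2 is a 1.6-fold lower number from compound 1 to compound 2 (0.21 log units; within the scatter), the move to compound 3 is a 5.8-fold lower number from compound 1 to compound 3 (0.76 log units; beyond the scatter), and between those two sits a 3.6-fold lower number from compound 2 to compound 3 (0.56 log units; beyond the scatter). So the group on the saturated chain carbon bound to an aromatic carbon and a saturated chain carbon can be exchanged without loss, and one exchange brings a clear gain.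

Among the measured compounds shown here, compound 4 `CC(C)C(/C=C1\CCNC1=O)c1ccc(-c2ccc3cccc(F)c3c2)[nH]c1=O` carries yet another group at this place. a group of 7 heavy atoms (5 carbon, 1 nitrogen, 1 oxygen; one five-membered non-aromatic ring with 1 hetero atom) in place of a group of 8 heavy atoms (4 carbon, 1 nitrogen, 2 oxygen, 1 sulfur; one six-membered non-aromatic ring with 2 hetero atoms), on a saturated chain carbon bound to an aromatic carbon and a saturated chain carbon Both earlier exchanges at this position bear on the question, but only loosely: the entering group here is a non-aromatic ring, whereas compounds 2 and 3 carry aromatic ones, and nothing measured so far shows what a non-aromatic ring does at this spot. A modest lowering of the number seems the most reasonable expectation, because a 1.6-fold lower number from compound 1 to compound 2 (0.21 log units; within the scatter) and a 5.8-fold lower number from compound 1 to compound 3 (0.76 log units; beyond the scatter) both ran in that direction. The expected step is therefore a 2.4-fold lower number from compound 1 to compound 4 (0.39 log units; beyond the scatter). Compound 4 is estimated to give 50 nM, with a range from 15 nM to 180 nM.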

Compound 4, half-maximal inhibitory concentration: 8.7 nM
Beside the measured number, compound 4's estimate is 5.7-fold (0.76 log units) above it; measured number below the stated range.
By their numbers in this assay, from the lowest: compound 4; then compound 3; then compounds 2 and 1 (each within the scatter of the next).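

At the saturated chain carbon bound to an aromatic carbon and a saturated chain carbon, an aromatic ring is not needed for a gain: in this assay, the five-membered non-aromatic ring with 1 hetero atom gives the largest step yet seen at this place (a 14-fold lower number from compound 1 to compound 4 (1.15 log units; beyond the scatter)). This group also improves on both groups that carry a five-membered aromatic ring (a 2.4-fold lower number from compound 3 to compound 4 (0.38 log units; beyond the scatter); an 8.7-fold lower number from compound 2 to compound 4 (0.94 log units; beyond the scatter)), which leaves compound 4 as the most potent of the four in this read-out. The leaving and entering groups differ in ring size, in their hetero atoms and in their count of hydrogen-bond donors, and no measured evidence is available to explain the gain.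

The compounds shown cannot separate the parts of the new group, so the roles of the amide hydrogen, the carbonyl and the double bond outside the ring remain open. As far as these compounds go, what an open-chain amide, a plain amine or a carboxylic acid would do on this carbon also remains unknown.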